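The compounds below may be only part of what the source reports. "The series", "measured", "known", "first", "only" and "open" are said of these compounds alone.

Compound 1 `COc1ccc(/C=C/C(=O)Nc2cc(C(=O)c3cc(OC)c(OC)c(OC)c3)ccc2OC)cc1`: 11100 nM
Compound 2 `COc1ccc(/C=C/C(=O)Nc2cc(C(=O)c3cc(OC)c(OC)c(OC)c3)cc(OC)c2OC)cc1`: 6300 nM

In a functional assay on PC-3 cells (Homo sapiens) for cytotoxicity, read by MTT assay, with a stated time of 72 h (a higher number here means a weaker inhibitor, a lower number a stronger inhibitor), compound 2 has the lower of the two numbers, yet the step of a 1.8-fold lower number from compound 1 to compound 2 (0.25 log units; within the scatter) lies within the scatter, so the two compounds cannot be ordered. Compound 3 `COc1cc(C(=O)c2cc(OC)c(OC)c(OC)c2)cc(NC(=O)/C=C/c2cc(F)c(F)c(F)c2)c1OC` differs from compound 2 by 3,4,5-trifluorophenyl in place of 4-methoxyphenyl on a double-bonded chain carbon bound to a double-bonded chain carbon. For the measured compounds named here, the one measured step concerns a methoxy group at another place on the shared core; nothing measured touches the group that changes here, so the data give no direction for this change. Compound 3 is therefore expected to show a step of a 1.1-fold higher number from compound 2 to compound 3 (0.05 log units; within the scatter), giving an estimate of 7000 nM within 2000 nM to 25000 nM.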

Compound 3, half-maximal inhibitory concentration: 7400 nM
Compound 3: the middle estimate sits 1.1-fold (0.02 log units) below what was measured, and the stated range covers the measured number.
By their numbers in this assay, from the lowest: compounds 2, 3 and 1 (each within the scatter of the next).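

Replacing 4-methoxyphenyl with 3,4,5-trifluorophenyl on the double-bonded chain carbon gives a 1.2-fold higher number from compound 2 to compound 3 (0.07 log units; within the scatter) in this assay. For the compounds shown here, this is the first measured change at this place, and these two differently substituted phenyl groups cannot be told apart here: neither can be ranked above the other. No supporting measurement bears on this result. From the compounds shown here alone, whether a group of another kind at this place, such as an amine or a carboxylic acid, would move the number beyond the scatter stays open.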